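From compound 2 to compound 4: starting from a limit

A few compounds are considered here, and "the series" means these few. Any claim that something is new, unique, unknown or untested is made for them only; others in the source may bear on it.

Measured values in an ADME assay on MT4 cells (Homo sapiens) for cytotoxicity, read by MTT assay; a lower number here means that less compound is tolerated, a higher number that more compound is tolerated:
compound 1 `Cc1cc(C)cc(S(=O)(=O)c2c(C(=O)NC(C)C(=O)NCCn3c(C)cnc3[N+](=O)[O-])[nH]c3ccc(Cl)cc23)c1` gives 16000 nM
compound 2 `Cc1cc(C)cc(S(=O)(=O)c2c(C(=O)NCc3cccc(N)c3)[nH]c3ccc(Cl)cc23)c1` gives > 53400 nM (a limit)
compound 3 `Cc1cc(C)cc(S(=O)(=O)c2c(C(=O)NC(c3ccc(Cl)cc3)C3CC3)[nH]c3ccc(Cl)cc23)c1` gives > 47300 nM (a limit)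

Compound 2 has no exact number in this assay and stands only at its limit of > 53400 nM. Compound 3 also stands only at a limit, > 47300 nM. Compound 4 `Cc1cc(C)cc(S(=O)(=O)c2c(C(=O)Nc3cc(C#N)ccn3)[nH]c3ccc(Cl)cc23)c1` has not yet been measured. It keeps the core of compound 2 and changes only the group on the amide-type nitrogen: 4-cyanopyridin-2-yl in place of 3-aminobenzyl on an amide-type nitrogen. In words, 4-cyanopyridin-2-yl takes the place of 3-aminobenzyl.

Going by the values given here, only one measured step bears on this nitrogen, a step that the two limits leave unreadable from compound 2 to compound 3, and it gives no size to carry over. Among the compounds with values here, the sole exact number comes from compound 1, at 16000 nM, so an exact reading for compound 4 is possible but cannot be derived from a measured step. The expected change is an at least 1.6-fold lower number from compound 2 to compound 4 (0.22 log units; that floor lies within the scatter), an estimate that leans modestly towards less compound being tolerated and remains very uncertain. Compound 4 may equally return only a limit. For compound 4 the estimated value is 32000 nM, with an expected range of 10000 nM to 54000 nM.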

Compound 4, half-maximal cytotoxic concentration: > 53700 nM
Compound 4 gave a limit, no number (the forecaster's own chance of this, stated with the estimate: 50%); middle value at least 1.6-fold (0.22 log units) from the limit.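

In this assay compound 4 gives > 53700 nM, which is a limit and not a number. Compound 2 and compound 3 also stand only at limits, and the steps from each of them to compound 4 cannot be read. The compounds shown leave open whether 4-cyanopyridin-2-yl in place of 3-aminobenzyl changes the read-out at all.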